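The source may hold more compounds than are shown below. What is called first, only, known or untested is meant among the compounds shown, and "the series" means these compounds.

Measured so far:
Compound 1 `Cc1ccnc(/C(N)=N/NC(=S)N2CCCC2)c1`: 80%
Compound 2 `Cc1cccc(/C(N)=N/NC(=S)N2CCCCC2)n1`: 63.2%

In a functional assay on A-375 cells (Homo sapiens) for cytotoxicity, read by MTT assay, with a stated time of 72 h, tested at 3 uM (on this read-out higher numbers stand for more inhibition of growth at the one concentration tested and lower numbers for less inhibition of growth), compound 1 gives 80%, the highest of the two numbers; the nearest is compound 2 with 63.2%, a gap that lies beyond the usual scatter of this kind of measurement. Compound 3 `Cc1ccnc(/C(N)=N/NC(=S)N2CCOCC2)c1` has not yet been measured. It differs from compound 1 in a single place: morpholin-4-yl in place of pyrrolidin-1-yl on a thiocarbonyl carbon. Within the data shown here, no pair of measured compounds differs from each other in only this way, so there is no measured step to lean on. With compound 1 at 80% as the starting point, a small loss, or no change beyond the scatter, is expected. The expected step of a number 12 percentage points lower from compound 1 to compound 3 (beyond the scatter) is therefore modest and downward. Compound 3 is expected to give about 68%, within a range from 45% to 88%.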

Compound 3, percent growth inhibition at one concentration: 66.6%
Estimate against measurement, compound 3: 1.4 percentage points above; the measured number falls inside the stated range.
By their numbers in this assay, from the lowest: compounds 2 and 3 (each within the scatter of the next); then compound 1.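

In this assay, the group on the thiocarbonyl carbon turns out to matter: placing morpholin-4-yl where pyrrolidin-1-yl stood gives a number 13.4 percentage points lower from compound 1 to compound 3 (beyond the scatter). Among these compounds, this is the first comparison in which only this group differs, yet the change itself has two parts, as the ring grows from five to six members and gains an oxygen atom, and the single step cannot separate them. Nothing available explains the drop in growth inhibition.

Going by these compounds, it remains open whether ring size or the oxygen atom accounts for the step, and a thiomorpholin-4-yl group at this place would help to tell them apart. On these data alone, it is also open how an open-chain group such as dimethylamino, without any ring, would compare on the core of compound 1.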